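A few compounds are considered here, and "the series" means these few. Any claim that something is new, unique, unknown or untested is made for them only; others in the source may bear on it.

Measured so far:
- compound 1 `CC(=O)NCc1cccc(Cn2nc(NS(=O)(=O)c3ccc(Cl)s3)c3c(F)cccc32)c1`: >= 139 ug/mL
- compound 2 `COc1cccc2c1c(NS(=O)(=O)c1ccc(Cl)s1)nn2Cc1cccc(CNC(=O)C2CCOCC2)c1`: >= 193 ug/mL

Both entries are limits rather than numbers. In a physicochemical assay for solubility, read by chemiluminescence, measured as kinetic solubility (on this read-out higher numbers stand for higher solubility and lower numbers for lower solubility), compound 2 stands at >= 193 ug/mL, and this is a limit of the assay. Compound 1 gives >= 139 ug/mL, which is also a limit.

Compound 3 `COc1cccc2c1c(NS(=O)(=O)c1ccc(Cl)s1)nn2Cc1cccc(CNC2COC2)c1` keeps the shared core of compound 2 and differs in one place: oxetan-3-yl in place of (oxan-4-yl)carbonyl on an amine nitrogen. In words, oxetan-3-yl stands in place of (oxan-4-yl)carbonyl on an amine nitrogen.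

Within the data shown here, no step between measured compounds is available to size this change, so the expectation is loose. No step beyond the usual scatter is expected in this assay, and no direction is favoured. The expected step is an at least 1.2-fold lower number from compound 2 to compound 3 (0.08 log units; that floor lies within the scatter). The estimate for compound 3 is 160 ug/mL, with an expected range of 90 ug/mL to 260 ug/mL.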

Compound 3, solubility: 122 ug/mL
Compound 3: the middle estimate sits 1.3-fold (0.12 log units) above what was measured; low and high end bracket the measured number.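

In this assay, among these compounds, compound 3 gives 122 ug/mL, the first reading that is a number and not a limit, so the amine nitrogen now has one exact value, with oxetan-3-yl on it. Compound 2 gives >= 193 ug/mL, which is a limit. Oxetan-3-yl in place of (oxan-4-yl)carbonyl on the amine nitrogen therefore reads only as an at least 1.5-fold lower number from compound 2 to compound 3 (0.19 log units; that floor lies within the scatter), which fixes a floor within the usual scatter and leaves the full size of the step unknown: the limit of >= 193 ug/mL in this assay, at which 1 of the 3 values shown sits.

Still open, from the compounds shown here alone, is how a methyl group, a longer alkyl chain or a piperidin-4-yl group on the same amine nitrogen would read in this assay. Also open, going by these compounds, is whether the same change would give a comparable step on the core of compound 1.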